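A few compounds are considered here, and "the series" means these few. Any claim that something is new, unique, unknown or untested is made for them only; others in the source may bear on it.

Three compounds have been measured in an ADME assay on BTI cells for inhibition of Amine oxidase [flavin-containing] A (Homo sapiens), read by fluorescence and Amplex Red, with a stated time of 15 min, tested at 100 uM; a higher number here means more inhibition at the concentration tested (going by the name of the read-out), a lower number less inhibition:
compound 1 `C#CCN(C)CCCCOc1ccc2c(c1)CCC2=O` gives 7.93%;
compound 2 `C#CCN(C)CCCCCCOc1ccc2c(c1)CCC2=O` gives 4.42%;
compound 3 `C#CCN(C)CCCCOc1ccc2c(c1)CCCC2=O` gives 30.9%.

Compound 3 stands highest of the three numbers, with compound 1 nearest and compound 2 furthest, both gaps beyond the scatter. The unmeasured compound 4 `C#CCN(C)CCCCCOc1ccc2c(c1)CCCC2=O` differs from compound 3 by (methyl(propargyl)amino)methyl in place of methyl(propargyl)amino on a saturated chain carbon, four bonds along the chain from an oxygen on an aromatic ring. Among the compounds with values here, the one measured step that bears on this change is a number 3.5 percentage points lower from compound 1 to compound 2 (within the scatter), a change of the same kind at the same place, and it stayed within the scatter. On that basis the step from compound 3 to compound 4 in this assay is expected to be small, a number 4.9 percentage points lower from compound 3 to compound 4 (within the scatter), if anything slightly downward. Compound 4 is therefore estimated at 26%, with a range from 10% to 42%.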

Compound 4, a percentage reported as inhibition, at one concentration (the size of the read-out at that concentration, not a potency): 26.1%
The estimate for compound 4 lay 0.1 percentage points below the measured number; measured number inside the range.
By their numbers in this assay, from the lowest: compounds 2 and 1 (each within the scatter of the next); then compounds 4 and 3 (each within the scatter of the next).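

In this assay, (methyl(propargyl)amino)methyl in place of methyl(propargyl)amino gives a number 4.8 percentage points lower from compound 3 to compound 4 (within the scatter). Until now, lengthening this chain had been read only on the core of compound 1, where both numbers were low; this step shows the same kind of change staying within the scatter on the core of compound 3, at a higher level of inhibition. Nothing shown gives a reason for this result. From the compounds shown here alone, it remains open whether 2-(methyl(propargyl)amino)ethyl on the core of compound 3 would also stay within the scatter. Going by these compounds, it is equally open how a shorter chain, or a piperidine in place of methyl(propargyl)amino, would read.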